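A benzyl group replaces 2,4-dichlorobenzyl in compound 1

A few compounds are considered here, and "the series" means these few. Any claim that something is new, unique, unknown or untested is made for them only; others in the source may bear on it.

In a physicochemical assay for solubility (a lower number here means a less soluble compound, a higher number a more soluble compound), compound 1 `O=C(O)c1ccc(C(=O)/C(=C\c2ccc(F)c([N+](=O)[O-])c2)SCc2ccc(Cl)cc2Cl)cc1` gives only a limit, < 1000 ug/mL. Compound 2 `O=C(O)c1ccc(C(=O)/C(=C\c2ccc(O)c([N+](=O)[O-])c2)SCc2ccc(Br)cc2)cc1` also gives only a limit, < 1000 ug/mL. Compound 3 `O=C(O)c1ccc(C(=O)/C(=C\c2ccc(Br)c([N+](=O)[O-])c2)SCc2ccc(Cl)cc2Cl)cc1` likewise gives only a limit, < 1000 ug/mL. The evidence is thin: the limit of < 1000 ug/mL in this assay, at which 3 of the 3 values shown sit. Within the data shown here, the one measured step is a step that the two limits leave unreadable from compound 1 to compound 3, and it is bromo in place of fluoro on an aromatic carbon, elsewhere in the molecule. Compound 4 `O=C(O)c1ccc(C(=O)/C(=C\c2ccc(F)c([N+](=O)[O-])c2)SCc2ccccc2)cc1` differs from compound 1 as follows: phenyl in place of 2,4-dichlorophenyl on a saturated chain carbon bound to a sulfur. Among the measured compounds shown here, no measured step touches that place, so no step beyond the scatter is expected in this assay. The expected step is a step that the limit leaves unreadable from compound 1 to compound 4. The estimated value for compound 4 is 400 ug/mL, with an expected range from 60 ug/mL to 1000 ug/mL.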

Compound 4, solubility: < 1000 ug/mL
Compound 4: no number, only a limit; the forecaster's own chance of this, stated with the estimate: 85%; the middle value does not contradict the limit.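

In this assay no step can be read between compound 1 and compound 4, each giving only a limit. The compounds shown leave open how benzyl compares with 2,4-dichlorobenzyl, as everything rests on one limit: the limit of < 1000 ug/mL in this assay, at which 4 of the 4 values shown sit.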